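A longer carboxy chain on compound 2

A few compounds are considered here, and "the series" means these few. Any claim that something is new, unique, unknown or untested is made for them only; others in the source may bear on it.

In a functional assay on the whole organism for inhibition, with Rattus norvegicus as the target, read by paw edema, with stated times of 1 h and 3 h (a lower number here means that less compound is needed, a higher number that more compound is needed for the effect), two compounds sharing one core have been measured. Compound 1 (`C/C(=N\OCC(N)=O)c1ccc(Cl)cc1`) gives 24 mg/kg, and compound 2 (`C/C(=N\OCCC(=O)O)c1ccc(Cl)cc1`) gives 80 mg/kg, the higher of the two numbers. Going by the values given here, the only measured step, a 3.3-fold higher number from compound 1 to compound 2 (0.52 log units; beyond the scatter), is modest but beyond the scatter. It places carboxymethyl in place of carbamoyl on a saturated chain carbon bound to an oxygen.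

Compound 3 (`C/C(=N\OCCCCCC(=O)O)c1ccc(Cl)cc1`) carries 3-carboxypropyl in place of carboxy on a saturated chain carbon, two bonds along the chain from an oxygen. Among the compounds with values here, the step to compound 2 bears on this change only loosely, as it also replaces the end group, and no measured pair varies the chain alone. The data therefore give no firm direction, and no step beyond the scatter is expected in this assay, although a change of similar modest size either way remains possible. The expected change is a 1.1-fold lower number from compound 2 to compound 3 (0.06 log units; within the scatter). For compound 3 the estimated dose for half-maximal effect is 70 mg/kg, with an expected range of 25 mg/kg to 200 mg/kg.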

Compound 3, dose for half-maximal effect: 92 mg/kg
Estimate against measurement, compound 3: 1.3-fold (0.12 log units) below, within the range that was stated.
By their numbers in this assay, from the lowest: compound 1; then compounds 2 and 3 (each within the scatter of the next).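

In this assay, the exchange of carboxy for 3-carboxypropyl on a saturated chain carbon, two bonds along the chain from an oxygen, gives a 1.2-fold higher number from compound 2 to compound 3 (0.06 log units; within the scatter). Going by these compounds alone, this is the first measured pair in which the chain varies while the carboxylic acid at its end stays, and the group at this place grows from 3 heavy atoms to 6 without the two numbers separating beyond the scatter. The earlier step, a 3.3-fold higher number from compound 1 to compound 2 (0.52 log units; beyond the scatter), changed the end group and the chain together, so it could not show this; within these two compounds, the added chain carbons leave the dose for half-maximal effect unresolved from that of the shorter acid, and the data offer no measured basis for explaining this result.

The compounds shown leave open whether a carbamoyl group at the end of the longer chain would give a number near that of compound 1, which would separate the effect of the end group from that of the chain. They also leave open whether a much longer carboxy chain, a methyl ester or an amine at the chain end would move the number beyond the scatter.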